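Swapping the aryl group on the alkyne for a pentyl chain

A few compounds are considered here, and "the series" means these few. Any claim that something is new, unique, unknown or untested is made for them only; others in the source may bear on it.

Compound 1 `CC(=O)OCC(CCn1cc(C#Cc2cc(F)cc(F)c2)c(=O)n(C(=O)c2ccccc2)c1=O)COC(C)=O` and compound 2 `CC(=O)OCC(CCn1cc(C#Cc2ccc(Br)cc2)c(=O)n(C(=O)c2ccccc2)c1=O)COC(C)=O` share a core that carries an alkyne substituent. In a functional assay on MCF7 cells (Homo sapiens) for antiproliferative activity, read by MTT assay, with a stated time of 72 h (on this read-out lower numbers stand for stronger inhibition and higher numbers for weaker inhibition), compound 1 gives 28900 nM, and compound 2 gives 28900 nM; the step of no change at the digits printed from compound 1 to compound 2 (within the scatter) shows that exchanging one aryl group for another left the result unchanged. Compound 3 `CCCCCC#Cc1cn(CCC(COC(C)=O)COC(C)=O)c(=O)n(C(=O)c2ccccc2)c1=O` differs from compound 2 by pentyl in place of 4-bromophenyl on a triple-bonded carbon. Within the data shown here, no measured step covers an aryl-to-alkyl exchange, so the only guide is that this position tolerated change without effect. Compound 3 is therefore expected to stay near compound 2, at an estimated 35000 nM (range 10000 nM to 100000 nM), a step of a 1.2-fold higher number from compound 2 to compound 3 (0.08 log units; within the scatter) that is expected to be small.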

Compound 3, half-maximal inhibitory concentration: 62200 nM
The estimate for compound 3 lay 1.8-fold (0.25 log units) below the measured number; measured number inside the range.
By their numbers in this assay, from the lowest: compounds 1 and 2 (each within the scatter of the next); then compound 3.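

In this assay pentyl in place of either aryl group brings a 2.2-fold higher number from compound 2 to compound 3 (0.33 log units; beyond the scatter) and a 2.2-fold higher number from compound 1 to compound 3 (0.33 log units; beyond the scatter) so, unlike the exchange of one aryl group for another, this change at the triple-bonded carbon does move the result, though only modestly. The position therefore does not accept every group alike, and the two compounds with an aryl group hold the lower numbers. Nothing available explains this shift.

From the compounds shown here alone, whether losing the ring or the nature of the chain drives the step remains open. A cyclohexyl group, a longer chain or a chain ending in an amine could help separate these possibilities.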